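Aryl branching on the linker of compound 1

The compounds below may be only part of what the source reports. "The series", "measured", "known", "first", "only" and "open" are said of these compounds alone.

Working notes on the series. Compound 1 `COc1ccccc1N1CCN(CCCOc2ccc(C(=O)Nc3ccccc3OCCCC(=O)O)cc2)CC1` in an assay on Prostate gland (Oryctolagus cuniculus) for inhibition of Adrenergic receptor alpha-1 (Homo sapiens) (a lower number here means tighter binding, a higher number weaker binding), gives 100 nM. Compound 2 `COc1ccccc1N1CCN(CCCCCCOc2ccc(C(=O)Nc3ccccc3OCCCC(=O)O)cc2)CC1` in this assay gives 100 nM. On the digits shown compound 1 stands level with compound 2, its nearest neighbour; the two values lie within the scatter of each other, so the difference in chain length between them shows nothing. Going by the values given here, no step between measured compounds that differ in one place is available.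

Compound 3 `COc1ccccc1N1CCN(CCC(Oc2ccc(C(=O)Nc3ccccc3OCCCC(=O)O)cc2)c2ccc(CC(C)C)cc2)CC1` differs from compound 1 by 4-isobutylphenyl in place of hydrogen on a saturated chain carbon bound to an oxygen on an aromatic ring and a saturated chain carbon. Among the compounds with values here, no measured pair covers a change of this kind, so the direction is open; a step beyond the scatter cannot be ruled out in either direction, but the working expectation is a modest one, tending toward tighter binding. The estimated step from compound 1 to compound 3 is a 1.7-fold lower number from compound 1 to compound 3 (0.22 log units; within the scatter). Compound 3 is expected to give about 60 nM in this assay, within a range from 10 nM to 300 nM.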

Compound 3, dissociation constant: 2000 nM
Beside the measured number, compound 3's estimate is 33-fold (1.52 log units) below it; measured number outside the range, above it.
By their numbers in this assay, from the lowest: compounds 1 and 2 (each within the scatter of the next); then compound 3.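

At the saturated chain carbon bound to an oxygen on an aromatic ring and a saturated chain carbon, 4-isobutylphenyl in place of hydrogen moves the number in this assay toward weaker binding, with a 20-fold higher number from compound 1 to compound 3 (1.30 log units; beyond the scatter). Going by these compounds alone, this is the first step beyond the scatter, since compound 1 and compound 2 gave values within the scatter of each other, and it shows that this position is not indifferent to substitution. Nothing available bears on the reason for a step of this size.

Still open, going by these compounds, is whether the step belongs to the isobutyl group, to the aromatic ring or to any group at this carbon; a plain phenyl or a methyl group there would separate these. On these data alone, it is also open whether 4-isobutylphenyl gives the same step on the longer chain of compound 2.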